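Cytotoxicity notes on a bromophenyl ester analogue

The compounds below may be only part of what the source reports. "The series", "measured", "known", "first", "only" and "open" are said of these compounds alone.

The series shares one core, carried by compound 1 `COC(=O)c1c(Br)cc(Br)cc1OC(=O)COc1cc(O)c2c(=O)cc(-c3ccccc3)oc2c1`, compound 2 `COC(=O)c1cccc(OC)c1OC(=O)COc1cc(O)c2c(=O)cc(-c3ccccc3)oc2c1` and compound 3 `COC(=O)c1cccc(C)c1OC(=O)COc1cc(O)c2c(=O)cc(-c3ccccc3)oc2c1`, each with a differently substituted aryl ester on the side chain. In an ADME assay on cells (T-cell, Mus musculus, strain BALB/c) for cytotoxicity, read by MTT assay, with a stated time of 48 h (on this read-out lower numbers stand for higher toxicity in this test and higher numbers for lower toxicity in this test), compound 1 gives 398000 nM, compound 2 gives 196000 nM and compound 3 gives 299000 nM. On these numbers compound 3 sits among the other two, and its gaps to compound 1 and to compound 2 are each within the scatter, so the three compounds read alike in this assay. Among the compounds with values here, the only single-site change measured, a 1.5-fold higher number from compound 2 to compound 3 (0.18 log units; within the scatter), is likewise within the scatter.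

Compound 4 `COC(=O)c1cc(Br)ccc1OC(=O)COc1cc(O)c2c(=O)cc(-c3ccccc3)oc2c1` is not yet measured. It differs from compound 3 by a group of 11 heavy atoms (8 carbon, 2 oxygen, 1 bromine; one six-membered aromatic ring of carbon only) in place of a group of 11 heavy atoms (9 carbon, 2 oxygen; one six-membered aromatic ring of carbon only), on an oxygen next to a carbonyl group. Within the data shown here, no measured step replaces a methyl with a bromine; the nearest information is that compound 1, which also bears bromine on its aryl ester, and compound 3 show values whose gap is within the scatter, and that the swap from methoxy to methyl gave no step beyond the scatter. Compound 4 is therefore expected to show no step beyond the scatter in this assay, a 1.1-fold higher number from compound 3 to compound 4 (0.04 log units; within the scatter). The estimate for compound 4 in this assay is 330000 nM, with a range from 170000 nM to 650000 nM.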

Compound 4, half-maximal cytotoxic concentration: > 450000 nM
Compound 4 was reported as a limit; the forecaster's own chance of this, stated with the estimate: 5%; middle value at least 1.3-fold (0.13 log units) from the limit.
By their numbers in this assay, from the lowest: compounds 2, 3 and 1 (each within the scatter of the next, the first and the last beyond it). At a limit, above all of these: compound 4.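

In this assay, within the data shown here, placing the 4-bromo-2-(methoxycarbonyl)phenyl group on an oxygen next to a carbonyl group gives an at least 1.5-fold higher number from compound 3 to compound 4 (0.17 log units; that floor lies within the scatter), the first step that has a floor and no measured size. This change therefore does not move the read-out towards higher toxicity in this test, which the earlier single-site step, from methoxy to methyl, could not show for a bromine-bearing aryl ester. Compound 4 stands as a limit and not as a number: the limit of > 450000 nM in this assay, at which 1 of the 4 values shown sits.

Going by these compounds, how far compound 4 really lies from compound 3 stays open, and so does whether that gap would exceed the scatter once a number replaces the limit. Also open, on these data alone, is how the read-out would respond on this aryl ester to an amine, or to a carboxylic acid in place of the methoxycarbonyl group.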